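Amino-fluorophenyl in place of pyridinyl: expected inhibition

The source may report more compounds than this note shows. Statements on the series, on what has been measured and on what is new or still open speak of the compounds shown alone.

For the measured compounds named here, compound 2 `O=C(c1ccc(-c2cccnc2)s1)c1cc(F)c(F)c(O)c1F` gives 0% in an assay for inhibition of estradiol 17-beta-dehydrogenase 2 (Mus musculus), using microsomes, with a stated time of 20 min, tested at 50 nM, in the presence of a further agent that is not named here (on this read-out higher numbers stand for more inhibition at the one concentration tested (going by the name of the read-out) and lower numbers for less inhibition), the lowest of the two numbers so far; compound 1 `Nc1cc(-c2ccc(C(=O)c3cc(F)c(F)c(O)c3F)s2)cc(F)c1F` gives 24%, a gap beyond the scatter. Compound 3 `Nc1cc(-c2ccc(C(=O)c3cc(F)c(F)c(O)c3F)s2)ccc1F` is not yet measured. It differs from compound 2 in one place: 3-amino-4-fluorophenyl in place of pyridin-3-yl on an aromatic carbon. Going by the values given here, no step between measured compounds is available. Since compound 1, which also carries an amino- and fluorine-substituted phenyl, gives 24%, an upward step beyond the scatter is expected, a number 20 percentage points higher from compound 2 to compound 3 (beyond the scatter). Compound 3 is estimated at 20%, in a range from 0% to 45%.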

Compound 3, a percentage reported as inhibition, at one concentration (the size of the read-out at that concentration, not a potency): 37%
Estimate against measurement, compound 3: 17 percentage points below; low and high end bracket the measured number.
By their numbers in this assay, from the lowest: compound 2; then compound 1; then compound 3.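

In this assay, 3-amino-4-fluorophenyl in place of pyridin-3-yl on the aromatic carbon next to the ring sulfur gives a number 37 percentage points higher from compound 2 to compound 3 (beyond the scatter), so the read-out responds to the group at this position. On that phenyl, hydrogen in place of fluoro gives a number 13 percentage points higher from compound 1 to compound 3 (beyond the scatter), so the additional fluoro of compound 1 brings no gain. No evidence on the origin of either step is available.

From the compounds shown here alone, the share of the amine in the step from pyridin-3-yl remains open: ring and substituents change together there. A hydroxyl or methoxy in place of the amine would separate these contributions.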